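A few compounds are considered here, and "the series" means these few. Any claim that something is new, unique, unknown or untested is made for them only; others in the source may bear on it.

Working notes on the series in a functional assay on A-375 cells (Homo sapiens) for inhibition, read by MTT assay, with a stated time of 120 h; a higher number here means a weaker inhibitor, a lower number a stronger inhibitor. Of the compounds shown here, two have numbers so far. Compound 1 `CC(NC(=O)C#Cc1ccc(NC(=O)Nc2cc(C(F)(F)F)ccc2Cl)cc1)c1ccccc1` gives 30500 nM in this assay. Compound 2 `O=C(/C=C/c1ccc(NC(=O)Nc2ccc(Cl)c(C(F)(F)F)c2)cc1)NC1CCC1` gives 15400 nM in this assay. Compound 2 carries the lower of the two numbers, but its gap to compound 1 lies within the scatter of the measurement, so the two cannot be ordered against each other on this evidence.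

Compound 3 `CNC(=O)/C=C/c1ccc(NC(=O)Nc2ccc(Cl)c(C(F)(F)F)c2)cc1` has not been measured. It differs from compound 2 in one place: methyl in place of cyclobutyl on an amide-type nitrogen. For the measured compounds named here, no pair of measured compounds shows this change, so there is no measured step to lean on, and the two values above are the only anchor. Both measured compounds sit in the same weak region, and the change on the amide nitrogen is a small one in size, so for compound 3 a step of at most the usual scatter is expected, with no clear direction. The estimate for compound 3 is 20000 nM, with a range from 7000 nM to 55000 nM. The step this expectation implies, a 1.3-fold higher number from compound 2 to compound 3 (0.11 log units; within the scatter), is expected to stay within the scatter.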

Compound 3, half-maximal inhibitory concentration: 20900 nM
Compound 3: the middle estimate sits 1.0-fold (0.02 log units) below what was measured, and the stated range covers the measured number.
By their numbers in this assay, from the lowest: compounds 2, 3 and 1 (each within the scatter of the next).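

Swapping cyclobutyl for methyl on the amide-type nitrogen gives, in this assay, a 1.4-fold higher number from compound 2 to compound 3 (0.13 log units; within the scatter), the first measured step at this position. On this one pair, the four-membered ring of carbon only can be given up for methyl with no change that the assay can resolve, and the number stays in the same weak region. No measured information is available to explain this outcome.

Going by these compounds, both groups at this position are plain carbon substituents carrying no hydrogen-bond donors or acceptors, so it remains open whether a primary amine or a carboxylic acid at the end of a longer chain on the same nitrogen would move the number beyond the scatter. Compound 1 differs from the other two compounds in more than one place, so the alkyne linker, the arrangement of the chloro and trifluoromethyl groups and the 1-phenylethyl group on its amide cannot be assessed separately, and whether any of them matters here remains unresolved.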